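The compounds below may be only part of what the source reports. "The series", "measured", "known", "first", "only" and "open" are said of these compounds alone.

Measured so far:
Compound 1, `COc1ccc(-c2cc(/C=C/C(=O)c3ccc(OC)c(OC)c3)[nH]n2)cc1`, in a functional assay on CAKI-1 cells (Homo sapiens) for cytotoxicity, read by sulforhodamine B assay, with a stated time of 48 h, tested at 100 uM (a higher number here means a weaker effect of the compound at the concentration tested, a lower number a stronger effect), gives -70%.
Compound 2, `COc1cc(-c2cc(/C=C/C(=O)c3ccc(Cl)c(Cl)c3)[nH]n2)cc(OC)c1OC`, in this assay gives 11%.

Compound 2 stands at the highest of the two numbers in this assay; its nearest neighbour is compound 1, whose value lies far lower, a gap beyond the scatter. Within the data shown here, no step between compounds that differ in one place is available, so the two values show only that these two compounds behave very differently in this read-out.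

Compound 3, `COc1cc(-c2cc(/C=C/C(=O)c3ccc(F)c(F)c3)[nH]n2)cc(OC)c1OC`, has not yet been measured. It differs from compound 2 in one place: 3,4-difluorophenyl in place of 3,4-dichlorophenyl on a carbonyl carbon. Among the measured compounds shown here, with no comparable step among the measured compounds, the size of this change cannot be read from them. A small step, if any, is expected in this assay, close to the scatter and of uncertain direction, and the expected step is a number 4 percentage points higher from compound 2 to compound 3 (within the scatter). For compound 3 the estimated value is 15%, within a range from -30% to 50%.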

Compound 3, a percentage reported as activity, at one concentration (the size of the read-out at that concentration, not a potency): 3%
Compound 3: the middle estimate sits 12 percentage points above what was measured; the range from low to high includes it.
By their numbers in this assay, from the lowest: compound 1; then compounds 3 and 2 (each within the scatter of the next).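

Among these compounds, the step in this assay is the first that can be read at this position: with 3,4-difluorophenyl in place of 3,4-dichlorophenyl on a carbonyl carbon, the result is a number 8 percentage points lower from compound 2 to compound 3 (within the scatter) on the shared core. The two groups match in heavy atoms and ring and differ only in carrying fluorine or chlorine, and this exchange of one halogen for the other does not separate the two compounds in this read-out. Nothing at hand bears on why that is so.

From the compounds shown here alone, whether a group of another kind at this carbonyl carbon, such as an unsubstituted phenyl or a phenyl ring carrying an amine or a carboxylic acid, would move the value beyond the scatter remains open. Among the compounds shown here, compound 1 differs from the other two in more than one place, so no step to it can be read.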